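Urea to amide on the dichlorophenyl side: compound 3

This account rests on a few compounds, and the source may have more. Where it says the series, first, only, none or still open, it means among the compounds named here.

Within the data shown here, compound 2 `COc1cc2c(cc1N1C[C@@H](C)N(C)[C@@H](C)C1)N(C(=O)Nc1cccc(Cl)c1Cl)CC2` gives 79.4 nM in an assay on isolated protein for binding affinity to 5-hydroxytryptamine receptor 1D (Homo sapiens) (a higher number here means a weaker inhibitor, a lower number a stronger inhibitor), the higher of the two numbers known so far. Among the measured compounds shown here, compound 1 `COc1cc2c(cc1N1CCN(C)CC1)N(C(=O)Nc1cccc(Cl)c1Cl)CC2` gives 12.6 nM in this assay, and the step of a 6.3-fold higher number from compound 1 to compound 2 (0.80 log units; beyond the scatter) is the only measured comparison. Compound 3 `COc1cc2c(cc1N1C[C@@H](C)N(C)[C@@H](C)C1)N(C(=O)c1cccc(Cl)c1Cl)CC2` differs from compound 2 in one place: 2,3-dichlorophenyl in place of (2,3-dichlorophenyl)amino on a carbonyl carbon. For the measured compounds named here, no measured step bears on this change; the step from compound 1 to compound 2 concerns the ring on the aromatic carbon, not the carbonyl side, so it gives no guidance here. Without a relevant precedent, the expectation for compound 3 can only be loose. Compound 3 is expected to give 160 nM in this assay, within a range of 40 nM to 630 nM. This estimate means a step of a 2.0-fold higher number from compound 2 to compound 3 (0.30 log units; within the scatter) from compound 2 to compound 3, and the number could fall on either side of it.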

Compound 3, inhibition constant: 251 nM
Compound 3: middle estimate off by 1.6-fold (0.20 log units), on the low side, within the range that was stated.
By their numbers in this assay, from the lowest: compound 1; then compound 2; then compound 3.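

On the carbonyl carbon, replacing (2,3-dichlorophenyl)amino with 2,3-dichlorophenyl gives a weaker compound in this assay, with a 3.2-fold higher number from compound 2 to compound 3 (0.50 log units; beyond the scatter) as the step. Among these compounds, this is the first reading on the carbonyl side of the series, as the earlier step concerned only the ring on the aromatic carbon. The change removes one nitrogen and one hydrogen-bond donor, so binding here is sensitive to the group on the carbonyl, although the data do not separate the contribution of the nitrogen from that of its hydrogen, and no supporting evidence accounts for the loss.

Going by these compounds, this single pair carries 3,4,5-trimethylpiperazin-1-yl, so the size of the step with 4-methylpiperazin-1-yl remains open. Also open, on these data alone, is how a linker such as an oxygen or a methylene, in the place of the amino nitrogen, would compare.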